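A few compounds are considered here, and "the series" means these few. Any claim that something is new, unique, unknown or untested is made for them only; others in the source may bear on it.

Compound 1 `O=C(Nc1ccc(S(F)(F)(F)(F)F)cc1)c1ccc(S(=O)(=O)c2ccc(O)cc2)cc1`: 10900 nM
Compound 2 `O=C(Nc1cccc(S(F)(F)(F)(F)F)c1)c1ccc(S(=O)(=O)c2ccc(O)cc2)cc1`: 6010 nM
Compound 3 `O=C(Nc1ccc(C(F)(F)F)cc1)c1ccc(S(=O)(=O)c2ccc(O)cc2)cc1`: 30700 nM

All three were tested in a functional assay on DU-145 cells (Homo sapiens) for antiproliferative activity, read by fluorescence and propidium iodide staining, with a stated time of 96 h; on this read-out higher numbers stand for weaker inhibition and lower numbers for stronger inhibition. Compound 1 and compound 2 are built from the same atoms joined differently; the difference between their two cores is not broken down here, and their two values lie within the scatter of each other. From compound 1 to compound 3 the change is a group of 4 heavy atoms (1 carbon, 3 fluorine; no ring) in place of a group of 6 heavy atoms (5 fluorine, 1 sulfur; no ring), on an aromatic carbon and it made the step of a 2.8-fold higher number from compound 1 to compound 3 (0.45 log units; beyond the scatter).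

Compound 4 `O=C(Nc1cccc(C(F)(F)F)c1)c1ccc(S(=O)(=O)c2ccc(O)cc2)cc1` has not yet been measured in this assay. From compound 2 it differs by a group of 4 heavy atoms (1 carbon, 3 fluorine; no ring) in place of a group of 6 heavy atoms (5 fluorine, 1 sulfur; no ring), on an aromatic carbon. This is the same kind of change as before, but the place differs: para to a large group in the first case, meta to a large group here.

For compound 4 a step of a 2.8-fold higher number from compound 2 to compound 4 (0.45 log units; beyond the scatter) is expected, set beside the earlier one and resting on the step of a 2.8-fold higher number from compound 1 to compound 3 (0.45 log units; beyond the scatter). Compound 4 is therefore estimated at 17000 nM. For compound 4 the expected range runs from 8000 nM to 35000 nM.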

Compound 4, half-maximal inhibitory concentration: 17700 nM
The estimate for compound 4 lay 1.0-fold (0.02 log units) below the measured number; measured number inside the range.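

In this assay, putting trifluoromethyl in place of the group of five fluorines and one sulfur gave a 2.9-fold higher number from compound 2 to compound 4 (0.47 log units; beyond the scatter), and the two cores can be compared directly: the same change on two cores in this assay, a 2.8-fold higher number (0.45 log units; beyond the scatter) from compound 1 to compound 3 and a 2.9-fold higher number (0.47 log units; beyond the scatter) from compound 2 to compound 4, 1.0-fold (0.02 log units) apart, within the scatter of two such steps So across these two pairs the swap carried over with its size unchanged, whether the group sat meta to a large group or where it sits in compound 1. Two pairs in one cell assay do not show that the step would hold on any further core, and they do not explain why it has this size.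

From the compounds shown here alone, whether an amine, a carboxylic acid or a longer chain in that place would give a similar number remains open. Going by these compounds, all four compounds share the rest of the molecule, so the effect of changes elsewhere on this step also remains open.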